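A few compounds are considered here, and "the series" means these few. Any claim that something is new, unique, unknown or untested is made for them only; others in the source may bear on it.

Measured in an assay for inhibition of Fatty-acid amide hydrolase 1 (Rattus norvegicus); a higher number here means a weaker inhibitor, a lower number a stronger inhibitor:
Compound 1 `O=C(O)c1ccc(CCCCCCC(=O)c2ncc(-c3ccccn3)o2)cc1` gives > 600 nM; this is a limit of the assay, not a number.
Compound 2 `Nc1cccc(CCCCCCC(=O)c2ncc(-c3ccccn3)o2)c1` gives 30 nM.
Compound 3 `CS(=O)(=O)c1ccc(CCCCCCC(=O)c2ncc(-c3ccccn3)o2)cc1` gives 19 nM.

Among the two numbers in this assay, compound 3 has the lower one, but compound 2 with 30 nM sits within the usual scatter of compound 3 with 19 nM, so the two cannot be told apart. The value of compound 1 is only a limit of the assay. The compound to be measured next is compound 4 `Nc1ccc(CCCCCCC(=O)c2ncc(-c3ccccn3)o2)cc1`, and the change from compound 3 to it is amino in place of methylsulfonyl on an aromatic carbon. Within the data shown here, two measured steps bear on this change. The first is an at least 31-fold lower number from compound 1 to compound 3 (1.49 log units; beyond the scatter), which shows how far the number fell when the carboxy group left the ring. The second is an at least 20-fold lower number from compound 1 to compound 2 (1.30 log units; beyond the scatter), which shows that an amino group, even when placed elsewhere on the same ring, reached a number in the same region as compound 3. Taken together, these steps suggest that compound 4 will stay close to compound 3, with no step beyond the scatter expected in this assay. Compound 4 is therefore expected to give about 30 nM, most likely between 10 nM and 90 nM. That estimate amounts to an expected change of a 1.6-fold higher number from compound 3 to compound 4 (0.20 log units; within the scatter).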

Compound 4, inhibition constant: 3 nM
Compound 4: the middle estimate sits 10-fold (1.00 log units) above what was measured, and the stated range ends above it.
By their numbers in this assay, from the lowest: compound 4; then compounds 3 and 2 (each within the scatter of the next). At a limit, above all of these: compound 1.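

In this assay, amino in place of methylsulfonyl on this aromatic carbon, para to a large group, gives a 6.3-fold lower number from compound 3 to compound 4 (0.80 log units; beyond the scatter), which shows that the group at this place still has a clear effect on the number once the carboxy group has gone. Where the amino group sits on the ring matters as well: 4-aminophenyl in place of 3-aminophenyl gives a 10-fold lower number from compound 2 to compound 4 (1.00 log units; beyond the scatter), so the earlier amino compound did not show how low an amino-bearing ring could go in this series. Amino in place of carboxy gives an at least 200-fold lower number from compound 1 to compound 4 (2.30 log units; beyond the scatter), and this size is only a floor, since one end of the step is a limit of the assay and not a number: the limit of > 600 nM in this assay, at which 1 of the 4 values shown sits.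

As far as these compounds go, what stays open is whether the amino group itself is needed, for instance whether a methylamino, an acetylamino or a hydroxy group at the same place would reach a number as low as that of compound 4. From the compounds shown here alone, it is also open whether a shorter or a longer chain would keep that low number with the 4-aminophenyl group in place.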